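Mean residence time expected for an aroyl analogue

A few compounds are considered here, and "the series" means these few. Any claim that something is new, unique, unknown or untested is made for them only; others in the source may bear on it.

Compound 3 `Cc1cn(-c2cc(NC(=O)c3ccc(C)c(Oc4cccc5ccncc45)c3)cc(N3CCN(C)CC3)c2)cn1` gives 2.3 h in an ADME assay on the whole organism (Mus musculus, strain CD1), read by LC-MS, using cassette dosing, with a stated time of 24 h, at a dose of 0.4 mg/kg by the intravenous route (a higher number here means that the compound lasts longer, a lower number that the compound disappears faster), the lowest of the three numbers at hand. Compound 1 `Cc1cn(-c2cc(CN3CCN(C)CC3)cc(NC(=O)c3ccc(C)c(Nc4nccc(-c5ccccc5)n4)c3)c2)cn1` gives 2.66 h, within the scatter of compound 3, whereas compound 2 `Cc1cn(-c2cc(NC(=O)c3ccc(C)c(Oc4ccccc4)c3)cc(N3CCN(C)CC3)c2)cn1` gives 8.98 h; the step of a 3.9-fold lower number from compound 2 to compound 3 (0.59 log units; beyond the scatter) is the only one that touches the same place on the core. Compound 4 `Cc1cn(-c2cc(NC(=O)c3ccc(C)c(C(=O)c4cccc(C#N)c4)c3)cc(N3CCN(C)CC3)c2)cn1` differs from compound 3 by (3-cyanophenyl)carbonyl in place of (isoquinolin-8-yl)oxy on an aromatic carbon. For the measured compounds named here, no measured step makes this kind of exchange at that carbon, so the earlier step offers only a rough guide to how far the number can move. The step of a 1.3-fold higher number from compound 3 to compound 4 (0.12 log units; within the scatter) is therefore expected to stay within the scatter. Compound 4 is estimated at 3 h, with a range from 1.3 h to 7 h.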

Compound 4, mean residence time: 0.96 h
For compound 4 the middle estimate is 3.1-fold (0.49 log units) above the measured one; measured number below the stated range.
By their numbers in this assay, from the lowest: compound 4; then compounds 3 and 1 (each within the scatter of the next); then compound 2.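

In this assay the aromatic carbon ortho to a methyl group proves sensitive to more than the choice of aryl ether: (3-cyanophenyl)carbonyl brings a 2.4-fold lower number from compound 3 to compound 4 (0.38 log units; beyond the scatter) when it replaces (isoquinolin-8-yl)oxy and a 9.4-fold lower number from compound 2 to compound 4 (0.97 log units; beyond the scatter) when it replaces phenoxy . Both steps lie beyond the scatter, so a carbonyl-linked group at this carbon does not hold the number of either ether. Nothing measured here explains this fall. The compounds shown leave open whether the carbonyl or the nitrile goes with the lower number, since both enter together. An unsubstituted benzoyl group at this carbon would separate the two.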